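Replacing 2-fluoro-6-methylphenyl with 2-ethylphenyl in compound 4

A few compounds are considered here, and "the series" means these few. Any claim that something is new, unique, unknown or untested is made for them only; others in the source may bear on it.

In a physicochemical assay for solubility, in phosphate buffer, measured as kinetic solubility, at pH 7.4 (a higher number here means a more soluble compound, a lower number a less soluble compound), compound 3 `Cc1cccc(F)c1-c1nc(CN2CCC(C(=O)NCCCN3C[C@H](C)C[C@H](C)C3)CC2)c(C)o1` reads > 72 ug/mL, which is a limit and not a number. Compound 2 `Cc1oc(-c2ccc(Cl)cc2)nc1CN1CCC(C(=O)NCCCN2C[C@H](C)C[C@H](C)C2)CC1` reads > 72 ug/mL, also a limit. Within the data shown here, compound 1 `Cc1ccc(C)c(-c2nc(CN3CCC(C(=O)NCCCN4C[C@H](C)C[C@H](C)C4)CC3)c(C)o2)c1` gives the only actual number, 56.1 ug/mL, and the other two results form (the limit of > 72 ug/mL in this assay, at which 2 of the 3 values shown sit). Compound 4 `CCc1ccccc1-c1nc(CN2CCC(C(=O)NCCCN3C[C@H](C)C[C@H](C)C3)CC2)c(C)o1` carries 2-ethylphenyl in place of 2-fluoro-6-methylphenyl on an aromatic carbon. Two measured steps exchange the same group: an at least 1.2-fold higher number from compound 1 to compound 3 (0.10 log units; that floor lies within the scatter), and an at least 1.2-fold higher number from compound 1 to compound 2 (0.10 log units; that floor lies within the scatter). Neither shows a change beyond the scatter, so no step beyond the scatter is expected here. The expected step is an at least 1.1-fold lower number from compound 3 to compound 4 (0.06 log units; that floor lies within the scatter). For compound 4 the estimate is 62 ug/mL, with an expected range of 32 ug/mL to 90 ug/mL.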

Compound 4, solubility: 55.9 ug/mL
Beside the measured number, compound 4's estimate is 1.1-fold (0.04 log units) above it, and the stated range covers the measured number.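

In this assay, this position now has an exchange with a number on both sides, and it is a 1.0-fold lower number from compound 1 to compound 4 (0.00 log units; within the scatter), so 2-ethylphenyl and 2,5-dimethylphenyl read alike. Both an at least 1.2-fold lower number from compound 3 to compound 4 (0.10 log units; that floor lies within the scatter) and an at least 1.2-fold lower number from compound 2 to compound 4 (0.10 log units; that floor lies within the scatter) show no change beyond the scatter. These two steps remain floors because compound 2 and compound 3 each sit at a limit and not a number: the limit of > 72 ug/mL in this assay, at which 2 of the 4 values shown sit.

The compounds shown leave open how far compound 2 and compound 3 truly stand from compound 4. They also leave open how a phenyl ring carrying an amine or a carboxylic acid would read at this position.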